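The source may hold more compounds than are shown below. What is called first, only, known or untested is meant among the compounds shown, and "the series" means these compounds.

In an assay for inhibition of 15-hydroxyprostaglandin dehydrogenase [NAD(+)] (Homo sapiens), read by fluorescence, with a stated time of 15 min, in the presence of a further agent that is not named here (on this read-out higher numbers stand for weaker inhibition and lower numbers for stronger inhibition), three compounds have been measured so far. Compound 1 `CCCC[S+]([O-])c1sc2nc(-c3nccs3)cc(-c3ccc(C(C)(C)O)cc3)c2c1N` gives 3.6 nM, compound 2 `Nc1c([S+]([O-])CCCF)sc2nc(-c3cccs3)cc(-c3ccccc3)c12` gives 6.1 nM, and compound 3 `CCC[S+]([O-])c1sc2nc(-c3cccs3)cc(C(=O)N(C)C)c2c1N` gives 14.7 nM. Compound 2 holds the second highest of these three numbers: its value and that of compound 1 lie within the scatter of each other, while compound 3 stands beyond the scatter at a higher number, which means weaker inhibition.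

Compound 4 `Nc1c(C(=O)O)sc2nc(-c3cccs3)cc(-c3ccccc3)c12` has not yet been measured. It differs from compound 2 in one place: a group of 3 heavy atoms (1 carbon, 2 oxygen; no ring) in place of a group of 6 heavy atoms (3 carbon, 1 oxygen, 1 fluorine, 1 sulfur; no ring), on an aromatic carbon. All three measured compounds carry the group that leaves, and none carries a carboxy group. A step towards weaker inhibition, well beyond the scatter, is expected: a 49-fold higher number from compound 2 to compound 4 (1.69 log units; beyond the scatter). For compound 4 the estimate in this assay is 300 nM, with a range from 30 nM to 5000 nM.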

Compound 4, half-maximal inhibitory concentration: > 7500 nM
Compound 4 ended at the assay's limit (the forecaster's own chance of this, stated with the estimate: 25%); middle value at least 25-fold (1.39 log units) from the limit.
By their numbers in this assay, from the lowest: compounds 1 and 2 (each within the scatter of the next); then compound 3. At a limit, above all of these: compound 4.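

In this assay, replacing the group of 6 heavy atoms with a carboxy group, on the aromatic carbon next to the ring sulfur, gives an at least 1200-fold higher number from compound 2 to compound 4 (3.08 log units; beyond the scatter). Going by these compounds alone, all three earlier compounds carry the group that leaves, so only this pair shows that a single change at this place can cost nearly all measurable inhibition. The value of compound 4 is a limit and not a number: the limit of > 7500 nM in this assay, at which 1 of the 4 values shown sits.

The pair cannot separate the loss of the old group from the arrival of the carboxy group. A methyl ester or a primary amide on this carbon would help to tell these apart.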